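From Cyclopentyl to Cyclohexyl on the Amide Nitrogen

The source may report more compounds than this note shows. Statements on the series, on what has been measured and on what is new or still open speak of the compounds shown alone.

Three amides sharing one core have been measured in a functional assay on the whole organism (strain Wistar) for inhibition, with Rattus norvegicus as the target, read by paw edema, with stated times of 60 min and 4 h, at a dose of 100 mg/kg by the oral route; a lower number here means less inhibition, a higher number more inhibition at the dose given (going by the name of the read-out). Compound 1 `CCCCCNC(=O)CC1CCc2cc(OC)c(OC)cc21` gives 40.6% in this assay, and compound 2 `CCCCCCNC(=O)CC1CCc2cc(OC)c(OC)cc21` gives 42.1%. Compound 3 `COc1cc2c(cc1OC)C(CC(=O)NC1CCCC1)CC2` gives 45.3%, the highest of the three numbers, though its gap to each of the other two lies within the scatter: the step of a number 4.7 percentage points higher from compound 1 to compound 3 (within the scatter) and the step of a number 3.2 percentage points higher from compound 2 to compound 3 (within the scatter). On the numbers shown, compound 3 is thus not set apart from compounds 1 and 2.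

Compound 4 `COc1cc2c(cc1OC)C(CC(=O)NC1CCCCC1)CC2` has not yet been measured. Its difference from compound 3 is cyclohexyl in place of cyclopentyl on an amide-type nitrogen. Two kinds of measured step bear on it. The step of a number 1.5 percentage points higher from compound 1 to compound 2 (within the scatter), methyl in place of hydrogen on the chain, stayed within the scatter. The steps from pentyl and hexyl to cyclopentyl on the amide-type nitrogen likewise stayed within the scatter. Within the data shown here, nothing among the measured compounds indicates that cyclohexyl in place of cyclopentyl would behave otherwise, so the step of a number 0.7 percentage points higher from compound 3 to compound 4 (within the scatter) is expected to remain within the scatter. Compound 4 is accordingly estimated at 46% in this assay, within a range from 36% to 56%.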

Compound 4, a percentage reported as inhibition, in the whole organism at one dose (the size of the read-out at that dose, not a potency): 50%
The estimate for compound 4 lay 4 percentage points below the measured number, and the stated range covers the measured number.
By their numbers in this assay, from the lowest: compounds 1, 2, 3 and 4 (each within the scatter of the next).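

In this assay, the exchange of the five-membered carbon ring for the six-membered one on the amide-type nitrogen gives a number 4.7 percentage points higher from compound 3 to compound 4 (within the scatter), so this read-out does not separate cyclopentyl from cyclohexyl at this position. The comparisons with the open chains add that cyclohexyl is not separated from them either: cyclohexyl in place of hexyl gives a number 7.9 percentage points higher from compound 2 to compound 4 (within the scatter), and cyclohexyl in place of pentyl gives a number 9.4 percentage points higher from compound 1 to compound 4 (within the scatter). No measurement at hand speaks to the origin of these steps.

Among the four compounds, the substituents on this nitrogen are limited to saturated carbon groups, so it remains open whether a phenyl, a benzyl, or a chain carrying an amine or a carboxylic acid would give a step beyond the scatter. From the compounds shown here alone, with a single oral dose behind each number, it also remains open how these amides would compare at other doses.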